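This account rests on a few compounds, and the source may have more. Where it says the series, first, only, none or still open, it means among the compounds named here.

Measured compounds:
compound 1 `Cc1cc2cc(NS(=O)(=O)c3cc(C(=O)NO)ccc3Cl)ccc2n(C)c1=O` — 560 nM
compound 2 `COc1ccc(C(=O)NO)cc1S(=O)(=O)Nc1ccc2c(c1)cc(C)c(=O)n2C` — 443 nM
compound 3 `Cc1cc2cc(NCc3cc(C(=O)NO)ccc3Cl)ccc2n(C)c1=O` — 3190 nM

In an assay on isolated protein for inhibition of histone deacetylase 8 (Homo sapiens), read by fluorescence, with a stated time of 90 min (on this read-out lower numbers stand for stronger inhibition and higher numbers for weaker inhibition), compound 1 gives 560 nM and compound 2 gives 443 nM. The step of a 1.3-fold lower number from compound 1 to compound 2 (0.10 log units; within the scatter) arises from the change (methoxy in place of chloro on an aromatic carbon). Compound 3 rests on another core and gives 3190 nM in this assay; how its core differs from that of compound 1 is not broken down here. Compound 4 `COc1ccc(C(=O)NO)cc1CNc1ccc2c(c1)cc(C)c(=O)n2C` has not been measured in this assay. Among the measured compounds shown here, it differs from compound 3 by methoxy in place of chloro on an aromatic carbon, the same change as the one from compound 1 to compound 2, at the same place. On the strength of the step of a 1.3-fold lower number from compound 1 to compound 2 (0.10 log units; within the scatter), which lay within the scatter, the expected step is a 1.2-fold lower number from compound 3 to compound 4 (0.09 log units; within the scatter). Compound 4 is therefore estimated at 2600 nM in this assay, expected to fall between 1200 nM and 5500 nM.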

Compound 4, half-maximal inhibitory concentration: 555 nM
For compound 4 the middle estimate is 4.7-fold (0.67 log units) above the measured one; the whole stated range lies above it.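

In this assay, methoxy in place of chloro on an aromatic carbon gives a 5.7-fold lower number from compound 3 to compound 4 (0.76 log units; beyond the scatter). Among the compounds shown here, the size of this change therefore does not carry unaltered from one core to the other: the same change on two cores in this assay, a 1.3-fold lower number (0.10 log units; within the scatter) from compound 1 to compound 2 and a 5.7-fold lower number (0.76 log units; beyond the scatter) from compound 3 to compound 4, 4.5-fold (0.66 log units) apart, beyond the scatter of two such steps With only two pairs, this shows that the size of the step depended on the core here, but it does not show which difference between the cores matters or how the change would behave on any further core.

The compounds shown leave open how a fluoro, methyl or ethoxy group would compare with chloro and methoxy at this place on either core. They also leave open what a carboxylic acid in place of the hydroxycarbamoyl group would give.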